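Swapping a Naphthyl for a Methylphenyl Sulfonamide

The compounds below may be only part of what the source reports. "The series", "measured", "known", "first", "only" and "open" are said of these compounds alone.

Among the compounds with values here, compound 1 `O=C(O)CCC/C=C\C[C@H]1[C@@H]2CCC(C2)[C@@H]1NS(=O)(=O)c1cccc2ccccc12` is the only compound here with a numerical result in a functional assay (plasma) for inhibition, with Oryctolagus cuniculus as the target (on this read-out lower numbers stand for stronger inhibition and higher numbers for weaker inhibition), where compound 1 gives 1100 nM. A second compound, compound 2 `CC1(C)[C@H]2C[C@H](NC(=O)[C@H](O)C3CCCC3)[C@@H](C/C=C\CCCC(=O)O)[C@@H]1C2`, reaches no number in this assay: compound 2 gives > 800000 nM, which is a limit of the assay rather than a measured value. Within the data shown here, because of the limit of > 800000 nM in this assay, at which 1 of the 2 values shown sits, compound 1 is the sole true point of reference, and no step between measured compounds can be drawn.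

The unmeasured compound 3 `Cc1ccccc1S(=O)(=O)N[C@H]1C2CC[C@H](C2)[C@@H]1C/C=C\CCCC(=O)O` differs from compound 1 in one place: 2-methylphenyl in place of naphthalen-1-yl on a sulfonyl sulfur. Among the measured compounds shown here, no measured pair in this set carries the same change, so its effect cannot be read from the data and the expectation rests on compound 1 alone. The step is expected to move toward weaker inhibition, beyond the usual scatter but not dramatically, so that the step from compound 1 to compound 3 in this assay is estimated at a 3.2-fold higher number from compound 1 to compound 3 (0.50 log units; beyond the scatter). Compound 3 is therefore expected to give about 3500 nM in this assay, with a plausible range from 900 nM to 14000 nM.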

Compound 3, half-maximal inhibitory concentration: 6200 nM
Compound 3: middle estimate off by 1.8-fold (0.25 log units), on the low side; the measured number falls inside the stated range.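

The change from naphthalen-1-yl to 2-methylphenyl on a sulfonyl sulfur gives, in this assay, a 5.6-fold higher number from compound 1 to compound 3 (0.75 log units; beyond the scatter). Compound 1 alone could not show whether the aromatic group at this place matters, but this pair shows that it does: the group can be exchanged without losing a measurable result, yet the exchange costs some inhibition, and the step is modest rather than dramatic. The measured values offer nothing that explains why the step goes in this direction.

The change also does two things at once, since a second aromatic ring leaves and a methyl group arrives, so the compounds shown cannot say how much of the step belongs to each. On these data alone, a plain phenyl on the sulfonyl sulfur, carrying no methyl, would separate these two parts, and whether any other single-ring group can match naphthalen-1-yl at this place remains open.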